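Methyl removal on a fused core in an antiproliferative series

This account rests on a few compounds, and the source may have more. Where it says the series, first, only, none or still open, it means among the compounds named here.

Compound 1 `Cc1nsc2[nH]c(SCc3ccccc3)nc12` is the reference point of the series. In a functional assay on KB cells (Homo sapiens) for antiproliferative activity (on this read-out lower numbers stand for stronger inhibition and higher numbers for weaker inhibition), compound 1 gives 9000 nM. Compound 2 `c1ccc(CSc2nc3cnsc3[nH]2)cc1` differs from it by one change, (hydrogen in place of methyl on an aromatic carbon), and in this assay compound 2 gives 200 nM. That single change made a 45-fold lower number from compound 1 to compound 2 (1.65 log units; beyond the scatter).

Compound 3 `CSc1nc2c(C)nsc2n1[C@H]1C[C@H](O)[C@@H](CO)O1` carries a different core, and the difference between the two cores is not broken down here. In this assay compound 3 reaches only a limit, > 100000 nM, so no number is known for it; this is the limit described as the limit of > 100000 nM in this assay, at which 1 of the 3 values shown sits.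

Compound 4 `CSc1nc2cnsc2n1[C@H]1C[C@H](O)[C@@H](CO)O1` is not yet measured. It differs from compound 3 by hydrogen in place of methyl on an aromatic carbon, the same change as that from compound 1 to compound 2, at a place described in identical words.

Compound 4 is expected to move an at least 2.5-fold lower number from compound 3 to compound 4 (0.39 log units; beyond the scatter) in this assay, an expectation that rests on the earlier step of a 45-fold lower number from compound 1 to compound 2 (1.65 log units; beyond the scatter) and on the fact that compound 3 gives only a limit rather than a number. Compound 4 is therefore estimated at 40000 nM, between 5000 nM and 200000 nM.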

Compound 4, half-maximal inhibitory concentration: > 100000 nM
Compound 4 ended at the assay's limit; the forecaster's own chance of this, stated with the estimate: 50%; middle value at least 2.5-fold (0.39 log units) from the limit.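

The step from compound 3 to compound 4 cannot be read in this assay, since both compounds give a limit rather than a number: the limit of > 100000 nM in this assay, at which 2 of the 4 values shown sit.

The compounds shown leave open whether hydrogen in place of methyl changes activity at all on the core of compound 3, as it did on the core of compound 1.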